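The source may hold more compounds than are shown below. What is called first, only, known or untested is meant among the compounds shown, and "the series" means these compounds.

Measured in a physicochemical assay for lipophilicity, read by HPLC, measured as octanol-water partition, at pH 11; on this read-out lower numbers stand for lower lipophilicity and higher numbers for higher lipophilicity:

- compound 1, `CN(C)C(=O)c1cn(C)c2ccccc12`: 1.3
- compound 2, `COC(=O)c1ccc2c(C(=O)N(C)C)cn(C)c2c1`: 1.9
- compound 3, `COC(=O)c1ccc2ccc(C(=O)Nc3ccccc3)c-2cc1`: 4

Compound 1 stands lowest of the three. Its nearest neighbour is compound 2, reached by a number 0.60 log units higher from compound 1 to compound 2 (beyond the scatter), a change that puts methoxycarbonyl in place of hydrogen on an aromatic carbon. Compound 3 lies furthest from compound 1, a gap well beyond the scatter.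

Compound 4, `CN(C)C(=O)c1c[nH]c2ccccc12`, differs from compound 1 by hydrogen in place of methyl on an aromatic nitrogen. None of the measured steps touches this change; the only step shown concerns a methoxycarbonyl group on carbon, so nothing measured here bears on it directly. With one carbon leaving and no other difference, a small downward move in this assay is expected, possibly within the scatter.

For compound 4 the expected value is 0.9, with a range from 0.5 to 1.3, which means an estimated step of a number 0.40 log units lower from compound 1 to compound 4 (beyond the scatter).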

Compound 4, distribution coefficient: 0.4
Compound 4: the middle estimate sits 0.50 log units above what was measured; measured number outside the range, below it.
By their numbers in this assay, from the lowest: compound 4; then compound 1; then compound 2; then compound 3.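

In this assay, hydrogen in place of methyl on the aromatic nitrogen brings a number 0.90 log units lower from compound 1 to compound 4 (beyond the scatter) and so shows that this position, two ring bonds from the ring atom that bears the dimethylcarbamoyl group, moves the read-out. Compound 1 and compound 2 both carry methyl there, so neither could show this. Nothing available accounts for the size of the step.

On these data alone, how an ethyl group or a longer chain on that nitrogen would read remains open. So does whether the same change gives a similar step with methoxycarbonyl on the core.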